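The source may hold more compounds than are shown below. What is called first, only, known or untested is meant among the compounds shown, and "the series" means these compounds.

Measured in a functional assay on KMS-11 cells (Homo sapiens) for antiproliferative activity, read by CellTiter-Glo, with a stated time of 72 h; on this read-out higher numbers stand for weaker inhibition and lower numbers for stronger inhibition:
Compound 1 `COc1ccc(C(=O)N(Cc2ccncc2)Cc2cccc(OCC3CCCCC3)c2)cc1`: 19700 nM
Compound 2 `COc1ccc(C(=O)N(Cc2ccncc2)Cc2cccc(OCc3ccc(F)cc3)c2)cc1`: 22700 nM
Compound 3 `COc1ccc(C(=O)N(Cc2ccncc2)Cc2cccc(OCc3cccc(OC)c3)c2)cc1`: 16900 nM

Compound 3 does not stand apart from the other two. The comparisons show a 1.2-fold lower number from compound 1 to compound 3 (0.07 log units; within the scatter) and a 1.3-fold lower number from compound 2 to compound 3 (0.13 log units; within the scatter). The next structure, compound 4 `COc1ccc(C(=O)N(Cc2ccncc2)Cc2cccc(OCC(=O)c3cccc(Br)c3)c2)cc1`, has not yet been measured. It keeps the rest of compound 3 but carries (3-bromophenyl)carbonyl in place of 3-methoxyphenyl on a saturated chain carbon bound to an oxygen on an aromatic ring.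

The three measured steps at this same place bear on the change: the two above, and also a 1.2-fold higher number from compound 1 to compound 2 (0.06 log units; within the scatter). Swapping among cyclohexyl, 4-fluorophenyl and 3-methoxyphenyl therefore left the numbers in one narrow band. None of these compounds has a carbonyl or a bromine at this place, however, so those features remain untested and the range has to be wider than the measured steps alone would suggest. On this evidence, no step beyond the scatter is expected, and no direction can be favoured. The expected step is a 1.1-fold lower number from compound 3 to compound 4 (0.02 log units; within the scatter). Compound 4 is estimated at 16000 nM, with an expected range from 6000 nM to 35000 nM.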

Compound 4, half-maximal inhibitory concentration: 18700 nM
Estimate against measurement, compound 4: 1.2-fold (0.07 log units) below, and the stated range covers the measured number.
By their numbers in this assay, from the lowest: compounds 3, 4, 1 and 2 (each within the scatter of the next).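

In this assay, within the data shown here, the group (3-bromophenyl)carbonyl brings both a carbonyl and a bromine to this place on a saturated chain carbon bound to an oxygen on an aromatic ring, two features absent from the earlier compounds. The steps of a 1.1-fold higher number from compound 3 to compound 4 (0.04 log units; within the scatter) and a 1.2-fold lower number from compound 2 to compound 4 (0.08 log units; within the scatter) and a 1.1-fold lower number from compound 1 to compound 4 (0.02 log units; within the scatter) all lie within the scatter, so the four compounds cannot be put in a meaningful order, and the flat picture seen with cyclohexyl, 4-fluorophenyl and 3-methoxyphenyl now extends to a group with one more double bond outside the aromatic ring and one more heavy atom. No supporting measurement is available to explain why the number stays in this band.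

Compound 4 introduces the carbonyl and the bromine together, so the compounds shown cannot separate what each does alone, and a partner with only one of the two would be needed for that. On these data alone, it also remains open whether an amine, a carboxylic acid or a longer chain at this place would give a step beyond the scatter, or whether this position tolerates such groups just as evenly.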